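Removing the double bond from compound 2's acid chain

The source may report more compounds than this note shows. Statements on the series, on what has been measured and on what is new or still open speak of the compounds shown alone.

Of the compounds shown here, two with the same core have been measured in an ADME assay on the whole organism (strain CD-1) for pharmacokinetics, with Mus musculus as the target, at a dose of 3 mg/kg by the intravenous route; on this read-out lower numbers stand for slow clearance and higher numbers for fast clearance. In that assay, compound 1 `C/C(=C\CCCOc1ccccc1CN(C)C(=O)c1ccc(-c2ccco2)cc1)C(=O)O` gives 4 mL/min/kg and compound 2 `C/C(=C\C(=O)O)CCCOc1ccccc1CN(C)C(=O)c1ccc(-c2ccco2)cc1` gives 11 mL/min/kg, the higher of the two numbers. Among the measured compounds shown here, the only measured step is a 2.8-fold higher number from compound 1 to compound 2 (0.44 log units; beyond the scatter), a modest move beyond the usual scatter, with 2-carboxy-1-methylethenyl in place of 2-carboxyprop-1-en-1-yl.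

Compound 3 `CC(CCOc1ccccc1CN(C)C(=O)c1ccc(-c2ccco2)cc1)CCC(=O)O` has not yet been measured. Its difference from compound 2 is 3-carboxy-1-methylpropyl in place of 3-carboxy-2-methylprop-2-en-1-yl on a saturated chain carbon, two bonds along the chain from an oxygen on an aromatic ring. In words, this is 3-carboxy-1-methylpropyl in place of 3-carboxy-2-methylprop-2-en-1-yl, on a saturated chain carbon, two bonds along the chain from an oxygen on an aromatic ring.

For the measured compounds named here, the measured step also rearranges this chain, so it is the only guide, and it shows that such a rearrangement can move the number modestly. Going by the values given here, no measured compound has a fully saturated acid chain, so the direction remains open. The expected change is small, a 1.2-fold lower number from compound 2 to compound 3 (0.09 log units; within the scatter), and stays within the scatter. For compound 3 the estimate is 9 mL/min/kg, with an expected range from 4 mL/min/kg to 22 mL/min/kg.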

Compound 3, clearance: 4 mL/min/kg
The estimate for compound 3 lay 2.3-fold (0.35 log units) above the measured number, within the range that was stated.
By their numbers in this assay, from the lowest: compounds 1 and 3 (each within the scatter of the next); then compound 2.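

In this assay, replacing 3-carboxy-2-methylprop-2-en-1-yl with the saturated 3-carboxy-1-methylpropyl gives a 2.8-fold lower number from compound 2 to compound 3 (0.44 log units; beyond the scatter), so at this place on the chain a low number does not depend on keeping a double bond. Set against the other unsaturated chain, 3-carboxybut-2-en-1-yl, the same saturated chain gives no change at the digits printed from compound 1 to compound 3 (within the scatter), which means that one double-bond chain and the saturated chain cannot be told apart on this read-out, while the chain of compound 2 stands apart from both. Nothing available here explains why the chain of compound 2 behaves differently from the other two.

The step from the chain of compound 2 to the saturated chain changes the double bond and the place of the methyl group together, so these three compounds cannot show how much each change contributes on its own. As far as these compounds go, it also remains open how clearance would respond to a straight chain with no methyl group, to a longer chain, or to a tetrazole in place of the carboxylic acid.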